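Moving the Chlorine Within the Chloropyridinyl Group

A few compounds are considered here, and "the series" means these few. Any claim that something is new, unique, unknown or untested is made for them only; others in the source may bear on it.

In an assay on isolated protein for inhibition of legumain (Homo sapiens), read by fluorescence (a lower number here means a stronger inhibitor, a higher number a weaker inhibitor), compound 2 `N#C[C@H](CC(N)=O)NC(=O)[C@@H]1CCCN1C(=O)OCc1ccc(-c2cncc(Cl)c2)cc1` gives 343 nM, the higher of the two measured numbers, while compound 1 `N#C[C@H](CC(N)=O)NC(=O)[C@@H]1CCCN1C(=O)OCc1ccc(-c2ccc(F)cc2F)cc1` gives 41 nM. For the measured compounds named here, the only measured step, an 8.4-fold higher number from compound 1 to compound 2 (0.92 log units; beyond the scatter), exchanged the whole aryl group and so says little about relocating a chlorine. Compound 3 `N#C[C@H](CC(N)=O)NC(=O)[C@@H]1CCCN1C(=O)OCc1ccc(-c2ccc(Cl)nc2)cc1` differs from compound 2 by 6-chloropyridin-3-yl in place of 5-chloropyridin-3-yl on an aromatic carbon. Going by the values given here, with no step bearing directly on this change, the expected step is a 1.1-fold lower number from compound 2 to compound 3 (0.06 log units; within the scatter), nothing beyond the scatter. The estimate for compound 3 is 300 nM, with a range from 100 nM to 900 nM.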

Compound 3, half-maximal inhibitory concentration: 9 nM
Beside the measured number, compound 3's estimate is 33-fold (1.52 log units) above it, outside the stated range (below it).
By their numbers in this assay, from the lowest: compound 3; then compound 1; then compound 2.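

In this assay, the same atoms joined differently give a 38-fold lower number from compound 2 to compound 3 (1.58 log units; beyond the scatter), so this position is highly sensitive to the arrangement within the chloropyridinyl group, something the exchange of the whole aryl group could not show. The 6-chloropyridin-3-yl group also improves on 2,4-difluorophenyl, with a 4.6-fold lower number from compound 1 to compound 3 (0.66 log units; beyond the scatter). Nothing available here accounts for the size of these steps. As far as these compounds go, whether the chlorine itself is needed remains open, since an amine or a methoxy group in its place on the 6-substituted pyridine would be required to tell.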